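Replacing an anilino group with pyrrolidine: one step forward

This account rests on a few compounds, and the source may have more. Where it says the series, first, only, none or still open, it means among the compounds named here.

Measured in a functional assay on MCF7 cells (Homo sapiens) for inhibition, read by sulforhodamine B assay; on this read-out higher numbers stand for weaker inhibition and lower numbers for stronger inhibition:
- compound 1, `O=C1C=C(Nc2cccc(F)c2)C(=O)c2c1nc1n2[C@H]2OC[C@@H](O)[C@H]2OC1`, gives 5500 nM
- compound 2, `CCOc1ccccc1NC1=CC(=O)c2c(nc3n2[C@H]2OC[C@@H](O)[C@H]2OC3)C1=O`, gives only a limit of the assay, > 4000 nM
- compound 3, `O=C1C(Nc2cccc(Cl)c2)=CC(=O)c2c1nc1n2[C@H]2OC[C@@H](O)[C@H]2OC1`, gives 2970 nM

Compound 1 has the highest of the two actual numbers, and its nearest neighbour is compound 3; the gap between the two lies within the scatter, so neither can be called weaker or stronger. For compound 2 the result is a limit rather than a number (the limit of > 4000 nM in this assay, at which 1 of the 3 values shown sits). Among the compounds with values here, the single measured step, an at least 1.3-fold lower number from compound 2 to compound 3 (0.12 log units; that floor lies within the scatter), exchanges one aryl group on the amine nitrogen for another and stays within the scatter.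

Compound 4, `O=C1C=C(N2CCCC2)C(=O)c2c1nc1n2[C@H]2OC[C@@H](O)[C@H]2OC1`, differs from compound 1 in one place: pyrrolidin-1-yl in place of (3-fluorophenyl)amino on a double-bonded ring carbon. Within the data shown here, no measured step removes the amine hydrogen or brings in a saturated ring, so the change has no direct precedent; the only step at this position was small. The expected step is therefore no change at the digits printed from compound 1 to compound 4 (within the scatter), none beyond the scatter. Compound 4 is expected at 5500 nM, within a range from 1500 nM to 20000 nM.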

Compound 4, half-maximal inhibitory concentration: > 16000 nM
Compound 4: only a limit was reported; the forecaster's own chance of this, stated with the estimate: 35%; at least 2.9-fold (0.46 log units) between middle value and limit.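

Compound 4 gives only a limit of the assay rather than a number: the limit of > 16000 nM in this assay, at which 1 of the 4 values shown sits. Even so, this is the first change at this position to go beyond the scatter, with an at least 2.9-fold higher number from compound 1 to compound 4 (0.46 log units; beyond the scatter) in this assay, where a higher number stands for weaker inhibition. Within the data shown here, the earlier exchange of one aryl group for another on the amine nitrogen stayed within the scatter, so compound 4 is the first sign that inhibition depends on what sits on this ring carbon.

Pyrrolidin-1-yl lacks both the aromatic ring and the hydrogen-bond donor of (3-fluorophenyl)amino, so these compounds cannot separate the two. As far as these compounds go, a cyclohexylamino group, which keeps the amine hydrogen on a saturated ring, and a methyl(phenyl)amino group, which keeps the aromatic ring without that hydrogen, would each address one of them, and how either would read remains open.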